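The compounds below may be only part of what the source reports. "The series", "measured", "known", "first", "only" and "open" are said of these compounds alone.

Measured so far:
- compound 1 `COc1ccccc1N1C(=O)C(C)SC1c1cccc(C(=O)NCCCCc2ccccc2)c1`: 82%
- compound 2 `COc1ccc(OC)c(N2C(=O)CSC2c2cccc(C(=O)NCCCCc3ccccc3)c2)c1`: 5%
- compound 3 `COc1cccc(OC)c1N1C(=O)CSC1c1cccc(C(=O)NCCCCc2ccccc2)c1`: 80%

In a functional assay on HOS cells (Homo sapiens) for inhibition, read by CCK-8 assay, with a stated time of 72 h, tested at 1 uM (a higher number here means more inhibition at the concentration tested (going by the name of the read-out), a lower number less inhibition), compound 2 gives 5%, the lowest of the three numbers; compound 3 gives 80% and compound 1 gives 82%, both far above it. The step to compound 4 `Cc1cccc(N2C(=O)CSC2c2cccc(C(=O)NCCCCc3ccccc3)c2)c1` is 3-methylphenyl in place of 2,5-dimethoxyphenyl on an amide-type nitrogen in a ring. Within the data shown here, the one measured step that bears on this position is a number 75 percentage points higher from compound 2 to compound 3 (beyond the scatter), where the change of the group on that nitrogen from 2,5-dimethoxyphenyl to 2,6-dimethoxyphenyl took the number from a low one to a much higher one. So the group on this nitrogen matters greatly, but no measured compound carries a 3-methylphenyl, and nothing shows whether it behaves like the group in compound 2 or like those in compound 1 and compound 3. A rise beyond the scatter is expected, but with wide uncertainty. Compound 4 is estimated at 45%, within 5% to 85%, which means an expected step of a number 40 percentage points higher from compound 2 to compound 4 (beyond the scatter).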

Compound 4, a percentage reported as inhibition, at one concentration (the size of the read-out at that concentration, not a potency): 84%
Compound 4: middle estimate off by 39 percentage points, on the low side, within the range that was stated.
By their numbers in this assay, from the lowest: compound 2; then compounds 3, 1 and 4 (each within the scatter of the next).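

In this assay, putting 3-methylphenyl in place of 2,5-dimethoxyphenyl on the amide-type nitrogen in the ring gives a number 79 percentage points higher from compound 2 to compound 4 (beyond the scatter), so a high number on this core does not require a methoxy group on that phenyl ring. The comparison with the other high compound gives a number 4 percentage points higher from compound 3 to compound 4 (within the scatter), leaving 3-methylphenyl and 2,6-dimethoxyphenyl indistinguishable here, and among these three groups only the 2,5-dimethoxyphenyl of compound 2 stands apart. Nothing available explains why this one group gives so low a number.

Among these compounds, it remains open whether the low number needs both methoxy groups of that pattern or only the one written at position 5, which a 3-methoxyphenyl or 2,5-dimethylphenyl group could help separate. These readings at a single concentration also leave open how far the high compounds differ in potency.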